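The compounds below may be only part of what the source reports. "The series", "measured", "known", "first", "only" and "open" are said of these compounds alone.

Of the compounds shown here, two built on one shared core have been measured in an assay on membranes from brain for displacement of a labelled ligand from Sigma non-opioid intracellular receptor 1 (Cavia porcellus), read by scintillation counting, with a stated time of 120 min; a higher number here means a weaker inhibitor, a lower number a stronger inhibitor. Compound 1 `COC1Cc2c(csc2-c2ccccc2)C2(CCN(Cc3ccccc3)CC2)O1` gives 1 nM in this assay. Compound 2 `COC1Cc2c(csc2-c2ccc([N+](=O)[O-])cc2)C2(CCN(Cc3ccccc3)CC2)O1`, which carries a nitro group in place of a hydrogen on an aromatic carbon, gives 1 nM in this assay. The step of no change at the digits printed from compound 1 to compound 2 (within the scatter) shows that adding the nitro group left the inhibition constant unchanged within the scatter, so compound 2 stands level with compound 1 at the digits given.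

Compound 3 `COC1Cc2c(csc2-c2ccc(-c3ccccc3)cc2)C2(CCN(Cc3ccccc3)CC2)O1` has not yet been measured. It differs from compound 2 in one place: phenyl in place of nitro on an aromatic carbon. For the measured compounds named here, the only measured step that bears on this position is no change at the digits printed from compound 1 to compound 2 (within the scatter), which was flat within the scatter; it tells that a small group at this aromatic carbon is accepted without loss, but it gives no information about a phenyl ring there, which is a larger group. The expected step is therefore a 3.0-fold higher number from compound 2 to compound 3 (0.48 log units; beyond the scatter), a modest weakening. For compound 3 the estimated inhibition constant in this assay is 3 nM, with a range from 0.7 nM to 15 nM.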

Compound 3, inhibition constant: 30 nM
Estimate against measurement, compound 3: 10-fold (1.00 log units) below, and the stated range ends below it.
By their numbers in this assay, from the lowest: compounds 1 and 2 (each within the scatter of the next); then compound 3.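

In this assay the aromatic carbon that took a nitro group without any change does not accept every group: swapping nitro for phenyl gives a 30-fold higher number from compound 2 to compound 3 (1.48 log units; beyond the scatter) and swapping hydrogen for phenyl gives a 30-fold higher number from compound 1 to compound 3 (1.48 log units; beyond the scatter) as well. The flat step, no change at the digits printed from compound 1 to compound 2 (within the scatter), therefore did not mean that this carbon is indifferent to what it carries, as hydrogen and nitro sit level here while phenyl, with six heavy atoms and a ring in place of three heavy atoms and no ring, stands clearly apart from both. No measurement available here explains why the number rises.

The compounds shown leave open whether the ring itself or simply the larger number of atoms drives the rise, which a chlorine atom, a methoxy group or a short chain such as propyl at this carbon could begin to separate. They also leave open whether a saturated cyclohexyl ring or a pyridine ring in the same place would follow phenyl or stay level with hydrogen and nitro.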